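Ethoxy to methyl on the shared core

A few compounds are considered here, and "the series" means these few. Any claim that something is new, unique, unknown or untested is made for them only; others in the source may bear on it.

Values in a functional assay on HCT-116 cells (Homo sapiens) for antiproliferative activity, read by CellTiter-Glo, with a stated time of 10 days (on this read-out lower numbers stand for stronger inhibition and higher numbers for weaker inhibition), follow
- compound 1 `COCc1cc(-c2cnn(C)c2-c2sc3ccccc3c2C#N)cc2c(CN)n[nH]c(=O)c12` gives 51 nM
- compound 2 `Cn1ncc(-c2cc(Cl)c3c(=O)[nH]nc(CN)c3c2)c1-c1sc2ccccc2c1C#N` gives 734 nM
- compound 3 `CCOc1cc(-c2cnn(C)c2-c2sc3ccccc3c2C#N)cc2c(CN)n[nH]c(=O)c12` gives 637 nM

Compound 3 gives 637 nM and lies with compound 2 at the high end of the three numbers, well away from compound 1 (a 12-fold higher number from compound 1 to compound 3 (1.10 log units; beyond the scatter)). Compound 4 `Cc1cc(-c2cnn(C)c2-c2sc3ccccc3c2C#N)cc2c(CN)n[nH]c(=O)c12` carries methyl in place of ethoxy on an aromatic carbon. Among the compounds with values here, no measured step covers methyl itself. Methoxymethyl alone stands apart (a 14-fold higher number from compound 1 to compound 2 (1.16 log units; beyond the scatter)), while ethoxy in place of chloro changes nothing beyond the scatter (a 1.2-fold lower number from compound 2 to compound 3 (0.06 log units; within the scatter)). No step beyond the scatter is therefore expected in this assay, in either direction. The estimated step is small (a 1.4-fold lower number from compound 3 to compound 4 (0.15 log units; within the scatter)). For compound 4 the estimated value is 450 nM (expected range 120 nM to 1500 nM).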

Compound 4, half-maximal inhibitory concentration: 1470 nM
Beside the measured number, compound 4's estimate is 3.3-fold (0.51 log units) below it, and the stated range covers the measured number.
By their numbers in this assay, from the lowest: compound 1; then compounds 3, 2 and 4 (each within the scatter of the next, the first and the last beyond it).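

In this assay, methyl in place of ethoxy on this aromatic carbon gives a modest loss (a 2.3-fold higher number from compound 3 to compound 4 (0.36 log units; beyond the scatter)), so the position separates two groups in a way the chloro and ethoxy pair did not, while methyl and chloro stay level (a 2.0-fold higher number from compound 2 to compound 4 (0.30 log units; within the scatter)). Methoxymethyl remains alone here (a 29-fold higher number from compound 1 to compound 4 (1.46 log units; beyond the scatter)), with ethoxy, chloro and methyl all far from it. No measurement at hand bears on the cause of these steps.

Going by these compounds, whether a longer chain such as methoxyethyl, or an amine such as aminomethyl, would hold the number of compound 1 stays open.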